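Trifluoromethyl in Place of Chloro: From Compound 2 to Compound 3

The source may hold more compounds than are shown below. What is called first, only, known or untested is meant among the compounds shown, and "the series" means these compounds.

Of the compounds shown here, two sharing one core have been tested in a functional assay on MDA-MB-231 cells (Homo sapiens) for inhibition, read by MTT assay, with a stated time of 48 h; a lower number here means a stronger inhibitor of growth, a higher number a weaker inhibitor of growth. Compound 1 `S=C(NCc1ccccc1)Nc1ccc2ncnc(Nc3ccccc3Br)c2c1` returns > 30000 nM, which is a limit of the assay and not a number. Going by the values given here, compound 2 `S=C(Nc1ccc(Cl)cc1)Nc1ccc2ncnc(Nc3cccc(Br)c3)c2c1` gives 8200 nM in this assay, and this is the only number among the values shown; the other value sits at the limit of > 30000 nM in this assay, at which 1 of the 2 values shown sits. Compound 2 therefore stands alone as the sole measured point against which anything new can be set.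

Compound 3 `FC(F)(F)c1ccc(NC(=S)Nc2ccc3ncnc(Nc4cccc(Br)c4)c3c2)cc1` differs from compound 2 in one place: trifluoromethyl in place of chloro on an aromatic carbon. Among the compounds with values here, no pair of measured compounds shows what this change does in this assay, so the expected step from compound 2 to compound 3 is taken as a 1.2-fold lower number from compound 2 to compound 3 (0.07 log units; within the scatter), a change not beyond the usual scatter in either direction. On that basis compound 3 is expected to give about 7000 nM in this assay, with a range of 2500 nM to 20000 nM.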

Compound 3, concentration for 50% growth inhibition: 12200 nM
Estimate against measurement, compound 3: 1.7-fold (0.24 log units) below, within the range that was stated.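

With compound 3, this position, para to a large group, has its first measured step: in this assay, trifluoromethyl in place of chloro gives a 1.5-fold higher number from compound 2 to compound 3 (0.17 log units; within the scatter) and the two compounds cannot be told apart. The 4-chlorophenyl and 4-(trifluoromethyl)phenyl compounds therefore read alike here, so this one exchange does not separate the two groups at this position. Nothing among the data shown bears on why they read alike.

As far as these compounds go, whether an amine, a carboxylic acid or a methoxy group at this position would move the number beyond the scatter remains open. Going by these compounds alone, compound 1 gives > 30000 nM, which is a limit of the assay and not a number, and no step involving it can be read.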